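The compounds below may be only part of what the source reports. "The series", "measured", "known", "first", "only" and "open" are said of these compounds alone.

Working notes on the series, metabolic stability.

Three compounds of the series have been run in an ADME assay for metabolic stability, read by LC-MS, with a stated time of 3 h, at pH 6.5, tested at 50 uM; on this read-out higher numbers stand for a more stable compound and lower numbers for a less stable compound. Compound 1 `CCOC(=O)C1=C(S[C@@H]2CN[C@H](C(=O)Nc3cccc(C(=O)O)c3)C2)[C@H](C)[C@@H]2[C@@H]([C@@H](C)O)C(=O)N12` gives > 95% in this assay, which is a limit of the assay rather than a number. Compound 2 `C[C@@H](O)[C@H]1C(=O)N2C(C(=O)OCC(F)(F)F)=C(S[C@@H]3CN[C@H](C(=O)Nc4cccc(C(=O)O)c4)C3)[C@H](C)[C@H]12` likewise gives > 95% in this assay, again a limit. Compound 3 `CCOC(=O)c1cccc(NC(=O)[C@@H]2C[C@H](SC3=C(C(=O)O)N4C(=O)[C@H]([C@@H](C)O)[C@H]4[C@H]3C)CN2)c1` also gives > 95% in this assay, a limit once more.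

Compound 2 is derived from compound 1 by the change (trifluoromethyl in place of methyl on a saturated chain carbon bound to an oxygen next to a carbonyl group). The size of this step, a step that the two limits leave unreadable from compound 1 to compound 2, cannot be read because of the limit of > 95% in this assay, at which 3 of the 3 values shown sit. The cores of compound 1 and compound 3 are built from the same atoms joined differently; the difference between the two cores is not broken down here.

Compound 4 `C[C@@H](O)[C@H]1C(=O)N2C(C(=O)O)=C(S[C@@H]3CN[C@H](C(=O)Nc4cccc(C(=O)OCC(F)(F)F)c4)C3)[C@H](C)[C@H]12` has not yet been measured in this assay. Among the compounds with values here, it arises from compound 3 by trifluoromethyl in place of methyl on a saturated chain carbon bound to an oxygen next to a carbonyl group, which is the same change as the one from compound 1 to compound 2, made at the same place. The earlier step being unreadable, the expectation for compound 4 rests on compound 3 standing at the limit with > 95% and on the limit being where all three measured values sit. The step from compound 3 to compound 4 is therefore expected to be about a step that the limit leaves unreadable from compound 3 to compound 4. Compound 4 is estimated at 96% in this assay, with an expected range from 88% to 99%, and most likely a further limit rather than a number.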

Compound 4, percent of the compound remaining: > 95%
Compound 4 was reported as a limit; the forecaster's own chance of this, stated with the estimate: 80%; the middle value is on the limit's open side.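

The step from compound 3 to compound 4 cannot be read, just as the step from compound 1 to compound 2 could not, because both compounds of each pair stand at a limit of the assay rather than at a number: the limit of > 95% in this assay, at which 4 of the 4 values shown sit.

The compounds shown leave open whether trifluoromethyl in place of methyl changes the percent of compound remaining at all, and if so in which direction and by how much.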